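Swapping the Amide Substituent on a Thyroid Receptor Binder

The source may report more compounds than this note shows. Statements on the series, on what has been measured and on what is new or still open speak of the compounds shown alone.

Three compounds have been measured in an assay on isolated protein for inhibition of thyroid hormone receptor beta (Homo sapiens), read by fluorescence, with a stated time of 30 min; on this read-out lower numbers stand for stronger inhibition and higher numbers for weaker inhibition:
Compound 1 `CCCN(CC1CCOC1)C(=O)c1cc(Cl)c2oc(NCc3cccc(Cl)c3)nc2c1` gives 71 nM.
Compound 2 `CCCN(CC1CCOC1)C(=O)c1cc(OC)c2oc(NCc3cccc(Cl)c3)nc2c1` gives 12 nM.
Compound 3 `CCCc1cc(C(=O)N(CCC)CC2CCOC2)cc2nc(NCc3cccc(Cl)c3)oc12` gives 957 nM.

Compound 2 has the lowest number of the three and is the most potent, since a 5.9-fold lower number from compound 1 to compound 2 (0.77 log units; beyond the scatter) and an 80-fold higher number from compound 2 to compound 3 (1.90 log units; beyond the scatter) both lie beyond the scatter, as does a 13-fold higher number from compound 1 to compound 3 (1.13 log units; beyond the scatter). Compound 4 `COc1cc(C(=O)N2CCCC2(C)C)cc2nc(NCc3cccc(Cl)c3)oc12` keeps the methoxy of compound 2 and changes the amide side: 2,2-dimethylpyrrolidin-1-yl in place of ((oxolan-3-yl)methyl)(propyl)amino on a carbonyl carbon. Going by the values given here, none of the measured steps touches this part of the molecule; all three alter the group on an aromatic carbon. Among the compounds with values here, no measured step therefore bears directly on the change, and the expectation rests on the shared core alone. A step of a 3.3-fold higher number from compound 2 to compound 4 (0.52 log units; beyond the scatter) is expected in this assay, a moderate loss. Compound 4 is estimated at 40 nM, between 8 nM and 200 nM.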

Compound 4, half-maximal inhibitory concentration: 47 nM
The estimate for compound 4 lay 1.2-fold (0.07 log units) below the measured number; the range from low to high includes it.
By their numbers in this assay, from the lowest: compound 2; then compounds 4 and 1 (each within the scatter of the next); then compound 3.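

The earlier compounds shown here changed only the group on an aromatic carbon, whereas this first change on the carbonyl carbon gives, in this assay, a 3.9-fold higher number from compound 2 to compound 4 (0.59 log units; beyond the scatter). The amide side therefore also affects the number, and a rather different group still leaves compound 4 with measurable inhibition. The entering group has fewer heavy atoms than the leaving group and no hydrogen-bond acceptor, but nothing available explains the loss. As far as these compounds go, what a plain pyrrolidin-1-yl would give on this carbonyl carbon stays open, so the effect of the ring cannot be separated from that of its two methyl groups.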